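The source may report more compounds than this note shows. Statements on the series, on what has been measured and on what is new or still open speak of the compounds shown alone.

Working notes on the series. Among the measured compounds shown here, in a functional assay on MCF7 cells (Homo sapiens) for cytotoxicity, read by MTT assay, with a stated time of 96 h (on this read-out lower numbers stand for stronger inhibition and higher numbers for weaker inhibition), compound 2 (`COc1cc(C(=O)c2cn(-c3ccc(C)cc3)cc2-c2ccc([N+](=O)[O-])cc2)cc(OC)c1OC`) gives 200 nM as the higher of the two numbers measured so far. Compound 1 (`COc1cc(C(=O)c2cn(-c3cccc(N)c3)cc2-c2ccc(N)cc2)cc(OC)c1OC`) gives 14 nM in the same test, and the gap between the two lies beyond the scatter.

Compound 3 (`COc1cc(C(=O)c2cn(-c3ccc(C)cc3)cc2-c2ccc(N)cc2)cc(OC)c1OC`) has not yet been measured. It has amino in place of nitro on an aromatic carbon, para to a large group, so that 4-nitrophenyl becomes 4-aminophenyl (amino in place of nitro on an aromatic carbon). For the measured compounds named here, the series holds no measured one-place step to serve as a direct precedent for this change.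

In this assay the expected step of a 5.7-fold lower number from compound 2 to compound 3 (0.76 log units; beyond the scatter) runs toward a lower number and beyond the scatter. Going by the values given here, the only guide is compound 1 at 14 nM as a low reference, so the expectation remains loose. For compound 3 the estimated value is 35 nM (expected range 9 nM to 130 nM).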

Compound 3, half-maximal inhibitory concentration: 6 nM
For compound 3 the middle estimate is 5.8-fold (0.77 log units) above the measured one; the measured number lies below the stated range.
By their numbers in this assay, from the lowest: compound 3; then compound 1; then compound 2.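

In this assay, among the compounds shown here, the change of 4-nitrophenyl to 4-aminophenyl gives the first one-place step at this position, and it is large: a 33-fold lower number from compound 2 to compound 3 (1.52 log units; beyond the scatter). With 4-aminophenyl held in place, 4-methylphenyl in place of 3-aminophenyl on the aromatic nitrogen gives only a modest step, a 2.3-fold lower number from compound 1 to compound 3 (0.37 log units; beyond the scatter), so in these compounds the change from nitro to amino outweighs the change on that nitrogen. No independent evidence bears on the reason for either step.

As far as these compounds go, it remains open whether a dimethylamino group, an acetamide or a hydroxyl on the same aromatic carbon would keep the number as low as amino does. From the compounds shown here alone, it is also open whether the change from nitro to amino would give a step of similar size with 3-aminophenyl on the aromatic nitrogen.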